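This account rests on a few compounds, and the source may have more. Where it says the series, first, only, none or still open, it means among the compounds named here.

Compound 1 `Cc1ccc2oc(=O)c(/C=N/c3ccc(S(=O)(=O)Nc4nccs4)cc3)c(Cl)c2c1`: 33 nM
Compound 2 `Cc1ccc2oc(=O)c(/C=N/c3ccc(S(=O)(=O)Nc4nc(C)cc(C)n4)cc3)c(Cl)c2c1`: 25 nM

In a functional assay on MCF7 cells (Homo sapiens) for cytotoxicity, read by CCK-8 assay, with a stated time of 48 h (a lower number here means a stronger inhibitor, a higher number a weaker inhibitor), compound 2 gives 25 nM, and the number for compound 1 sits within the usual scatter of it, so the two cannot be ranked. Compound 3 `Cc1ccc2oc(=O)c(/C=N/c3ccc(S(=O)(=O)Nc4cc(C)on4)cc3)c(Cl)c2c1` differs from compound 2 by 5-methyl-1,2-oxazol-3-yl in place of 4,6-dimethylpyrimidin-2-yl on a sulfonamide nitrogen. Among the compounds with values here, the only measured step, a 1.3-fold lower number from compound 1 to compound 2 (0.12 log units; within the scatter), also exchanged one ring on that sulfonamide nitrogen for another and stayed within the scatter. A change of similar kind is therefore expected to move little, giving an expected step of a 1.4-fold higher number from compound 2 to compound 3 (0.15 log units; within the scatter). Compound 3 is estimated at 35 nM, with a range from 12 nM to 110 nM.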

Compound 3, half-maximal inhibitory concentration: 16 nM
Beside the measured number, compound 3's estimate is 2.2-fold (0.34 log units) above it; the range from low to high includes it.
By their numbers in this assay, from the lowest: compounds 3, 2 and 1 (each within the scatter of the next, the first and the last beyond it).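

In this assay the sulfonamide nitrogen now shows its first step beyond the scatter, though a modest one, with a 2.1-fold lower number from compound 1 to compound 3 (0.31 log units; beyond the scatter) when 5-methyl-1,2-oxazol-3-yl replaces 1,3-thiazol-2-yl. The same group in place of 4,6-dimethylpyrimidin-2-yl gives a 1.6-fold lower number from compound 2 to compound 3 (0.19 log units; within the scatter) and so these two cannot be ranked, showing that a five-membered and a six-membered aromatic ring can give similar numbers here. No measurement available here explains these differences.

All three groups on this nitrogen are aromatic rings containing nitrogen. Going by these compounds, whether such a ring is needed stays open, and a phenyl ring or a simple methyl group there would test this.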